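The compounds below may be only part of what the source reports. "The series", "measured", "known", "first", "only" and "open" are said of these compounds alone.

Measured so far:
- Compound 1 `CC(C)(C)C1=CC(=O)C=C(NCCC(=O)O)C1=O`: 28400 nM
- Compound 2 `CC1=CCC[C@H]2[C@](C)(CC3=CC(=O)C=C(N[C@@H](CC(C)C)C(=O)O)C3=O)[C@@H](C)CC[C@]12C`: 10900 nM

In a functional assay on Fem-X cells (Homo sapiens) for cytotoxicity, read by MTT assay, with a stated time of 72 h (on this read-out lower numbers stand for stronger inhibition and higher numbers for weaker inhibition), compound 2 has the lower of the two numbers at 10900 nM. Compound 1 stands higher at 28400 nM, a gap beyond the usual scatter of repeat measurements. Still unmeasured is compound 3 `CC1=CCC[C@H]2[C@](C)(CC3=CC(=O)C=C(NCC(=O)O)C3=O)[C@@H](C)CC[C@]12C`, which differs from compound 2 in one place: hydrogen in place of isobutyl on a saturated chain carbon bound to an amine nitrogen and a carbonyl carbon. In words, hydrogen replaces isobutyl on a saturated chain carbon bound to an amine nitrogen and a carbonyl carbon, so 1-carboxy-3-methylbutyl becomes carboxymethyl. For the measured compounds named here, no measured pair shows this change alone, so the guide is indirect. Compound 3 keeps the rest of compound 2 unchanged, so its number should stay near that of compound 2 at 10900 nM. The expected step, a 1.4-fold higher number from compound 2 to compound 3 (0.14 log units; within the scatter), is small, toward a slightly higher number and within the scatter. For compound 3 the estimate is 15000 nM, with an expected range from 6000 nM to 35000 nM.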

Compound 3, half-maximal inhibitory concentration: 17800 nM
Beside the measured number, compound 3's estimate is 1.2-fold (0.07 log units) below it; the range from low to high includes it.
By their numbers in this assay, from the lowest: compounds 2, 3 and 1 (each within the scatter of the next, the first and the last beyond it).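

Going from 1-carboxy-3-methylbutyl to carboxymethyl, with hydrogen in place of isobutyl on the saturated chain carbon bound to an amine nitrogen and a carbonyl carbon, gives in this assay a 1.6-fold higher number from compound 2 to compound 3 (0.21 log units; within the scatter). For the compounds shown here, this is the first direct reading of a single change in this set, and it shows that the isobutyl group, with its 4 carbon atoms, can give way to hydrogen without a difference that repeat measurements could tell apart. No measurement shown here offers an explanation for this result.

Still open, as far as these compounds go, is how a group of a different kind on this carbon, such as a phenyl ring or a basic amine, would read in this assay. Equally open, from the compounds shown here alone, is whether a primary amide in place of the carboxylic acid would leave the number just as undisturbed.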